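Fluoro in Place of Hydrogen on Compound 2

The source may report more compounds than this note shows. Statements on the series, on what has been measured and on what is new or still open speak of the compounds shown alone.

Measured so far in a physicochemical assay for lipophilicity, using the shake flask method, at pH 7.4; on this read-out higher numbers stand for higher lipophilicity and lower numbers for lower lipophilicity
- compound 1 `Cc1cc(OCCCS(C)(=O)=O)cc(C)c1-c1cccc(COc2ccc(OCC(=O)O)c(F)c2)c1` gives 2.31
- compound 2 `CC(Oc1ccccc1)C(=O)Nc1ccc(OCC(=O)O)c(F)c1` gives -0.18
- compound 3 `CC(C)(Oc1ccccc1)C(=O)Nc1ccc(OCC(=O)O)c(F)c1` gives "not determined" (no result reported)

Only two of these compounds have a number. Compound 2 (-0.18) holds the lower one, and compound 1 (2.31) lies well above it, a gap far beyond the usual scatter of repeated measurements. Compound 3 offers no number to compare.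

The next compound to be measured is compound 4 (`CC(Oc1ccccc1F)C(=O)Nc1ccc(OCC(=O)O)c(F)c1`), which differs from compound 2 in one place. The change (fluoro in place of hydrogen on an aromatic carbon) puts fluoro in place of hydrogen on an aromatic carbon, ortho to a large group, so that phenoxy becomes 2-fluorophenoxy. Within the data shown here, no measured pair here shows what this swap does in this assay, so the expectation has to start from compound 2 (-0.18), the close relative of compound 4. Since the rest of the structure stays the same, a small upward move is expected, and it may not clear the scatter. The estimate amounts to a shift of a number 0.18 log units higher from compound 2 to compound 4 (within the scatter) (an expected step, not a measured one). The expected value for compound 4 is 0 (estimated range -0.25 to 0.3).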

Compound 4, distribution coefficient: 0.07
Estimate against measurement, compound 4: 0.07 log units below; the range from low to high includes it.
By their numbers in this assay, from the lowest: compounds 2 and 4 (each within the scatter of the next); then compound 1.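

In this assay, among these compounds, this is the only pair in the set that isolates a single change, and fluoro in place of hydrogen on an aromatic carbon, ortho to a large group, gives a number 0.25 log units higher from compound 2 to compound 4 (within the scatter). A step of this size means that the phenoxy of compound 2 and the 2-fluorophenoxy of compound 4 cannot be told apart on this read-out, so this one pair gives no sign that the swap at this position matters for the measured distribution, although a single pair cannot settle that for other compounds. No supporting measurement is available that could explain the outcome at this position, so the result stands as an observation alone.

On these data alone, whether chloro, methoxy or an amine in the same place would give a step that clears the scatter remains open. Also open, as far as these compounds go, is whether fluoro on another carbon of this aromatic ring, or the same swap on the structure of compound 1, would leave the read-out just as close to its parent.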